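This account rests on a few compounds, and the source may have more. Where it says the series, first, only, none or still open, it means among the compounds named here.

Measured compounds:
Compound 1, `O=C1Nc2c(ccc(F)c2F)C1(c1ccccc1)c1ccc(O)cc1`: 7.1 nM
Compound 2, `Cc1ccc(C2(c3ccc(O)cc3)C(=O)Nc3c2ccc(F)c3F)cc1`: 1.7 nM
Compound 3, `O=C1Nc2ccccc2C1(c1ccc(O)cc1)C1CCCCCC1`: 247 nM

These three compounds were tested in a functional assay on MCF7 cells (Homo sapiens) for cytotoxicity, read by WST assay, with a stated time of 72 h; a lower number here means a stronger inhibitor, a higher number a weaker inhibitor. Compound 1 and compound 2 share one core and differ by a single change, (methyl in place of hydrogen on an aromatic carbon). That change gave a 4.2-fold lower number from compound 1 to compound 2 (0.62 log units; beyond the scatter). Compound 3 stands highest of the three numbers; how its core differs from the core of compound 1 is not broken down here.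

Compound 4, `Cc1cccc2c1NC(=O)C2(c1ccc(O)cc1)C1CCCCCC1`, has not yet been measured. It differs from compound 3 by methyl in place of hydrogen on an aromatic carbon. Among the measured compounds shown here, this is the same kind of change as the one from compound 1 to compound 2, but not the same: in compound 2 the methyl sits on a six-membered aromatic ring of carbon only, para to a large group, whereas in compound 4 it sits on an aromatic carbon of a six-membered aromatic ring of carbon only that is part of a fused or bridged system of two rings, ortho to a fused ring and meta to a fused ring. For the measured compounds named here, the earlier step is the only guide, and it was made at a different place on a different core. The expected step for compound 4 is therefore smaller and less certain than the measured one, a 1.5-fold lower number from compound 3 to compound 4 (0.19 log units; within the scatter), resting on the direction of a 4.2-fold lower number from compound 1 to compound 2 (0.62 log units; beyond the scatter) while allowing for the changed place. Compound 4 is estimated at 160 nM, with a likely range from 55 nM to 480 nM.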

Compound 4, half-maximal inhibitory concentration: > 1000 nM
Compound 4 was reported as a limit; the forecaster's own chance of this, stated with the estimate: 2%; at least 6.2-fold (0.79 log units) between middle value and limit.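

Compound 4 gives > 1000 nM in this assay, which is a limit of the assay and not a number. Methyl in place of hydrogen on an aromatic carbon gave an at least 4.0-fold higher number from compound 3 to compound 4 (0.60 log units; beyond the scatter), so this kind of change did not move the number the same way on both cores, and the two steps disagree: the same change on two cores in this assay, a 4.2-fold lower number (0.62 log units; beyond the scatter) from compound 1 to compound 2 and an at least 4.0-fold higher number (0.60 log units; beyond the scatter) from compound 3 to compound 4, at least 16-fold (1.22 log units) apart, beyond the scatter of two such steps

This shows that the gain seen on the core of compound 1 did not carry over to the core of compound 3, so in these two pairs the direction of the step could not be taken from one core to the other. It does not show what lies behind the reversal, as the methyl differs in both its place and its core, and two pairs cannot separate those two differences.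

The compounds shown leave open whether methyl on the aromatic carbon used in compound 4 would also raise the number on the core of compound 1, and whether methyl at the place used in compound 2 would lower it on the core of compound 3. They also leave open whether chlorine, a methoxy group or an amine on the aromatic carbon used in compound 4 would give a number that can be read on the scale of the assay.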